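The source may report more compounds than this note shows. Statements on the series, on what has been measured and on what is new or still open speak of the compounds shown alone.

Among the compounds with values here, in an ADME assay on microsomes from liver (Mus musculus) for metabolic stability, with a stated time of 10 min (a higher number here means that more of the compound is left, a lower number that less of the compound is left), compound 2 (`O=C(C1CCOCC1)N1CC[C@](c2ccc(C(OCc3c(F)cccc3F)(C(F)(F)F)C(F)(F)F)cc2)(S(=O)(=O)c2ccc(F)cc2)C1`) gives 29%, the lower of the two numbers measured so far, while compound 1 (`CC(=O)N1CCC(O)(C(=O)N2CC[C@](c3ccc(C(OCc4c(F)cccc4F)(C(F)(F)F)C(F)(F)F)cc3)(S(=O)(=O)c3ccc(F)cc3)C2)CC1`) gives 69%. Compound 3 (`CC(=O)N1CCN(C(=O)N2CC[C@](c3ccc(C(OCc4c(F)cccc4F)(C(F)(F)F)C(F)(F)F)cc3)(S(=O)(=O)c3ccc(F)cc3)C2)CC1`) has not yet been measured. Its difference from compound 2 is 4-acetylpiperazin-1-yl in place of oxan-4-yl on a carbonyl carbon, which places 4-acetylpiperazin-1-yl where oxan-4-yl stood on a carbonyl carbon. Within the data shown here, only one measured step bears on this change: a number 40 percentage points lower from compound 1 to compound 2 (beyond the scatter), with oxan-4-yl in place of 1-acetyl-4-hydroxypiperidin-4-yl on a carbonyl carbon. The group entering compound 3 carries an acetyl, as the group in compound 1 does, but the two groups are not the same, so only part of that large step is expected to be recovered. The expected change, in the upward direction and beyond the scatter, is a number 23 percentage points higher from compound 2 to compound 3 (beyond the scatter). For compound 3 the estimate is 52%, with an expected range of 30% to 75%.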

Compound 3, percent of the compound remaining: 59%
Estimate against measurement, compound 3: 7 percentage points below; measured number inside the range.
By their numbers in this assay, from the lowest: compound 2; then compounds 3 and 1 (each within the scatter of the next).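

In this assay, placing 4-acetylpiperazin-1-yl on the carbonyl carbon in place of oxan-4-yl gives a number 30 percentage points higher from compound 2 to compound 3 (beyond the scatter). Set against 1-acetyl-4-hydroxypiperidin-4-yl, the same group gives a number 10 percentage points lower from compound 1 to compound 3 (within the scatter), so at this position a group with no hydrogen-bond donor matches the group in compound 1 within the scatter. Among these three compounds, the two whose groups carry an acetyl both stand clearly apart from compound 2, which has none, although nothing measured here accounts for that difference.

As far as these compounds go, whether the acetyl itself carries the step remains open, since the ring changes along with it in each comparison. A piperazin-1-yl with a free amine, or with a methanesulfonyl group in place of the acetyl, would separate these two features in this assay.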